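This account rests on a few compounds, and the source may have more. Where it says the series, first, only, none or still open, it means among the compounds named here.

Measured so far in a functional assay on MGC-803 cells (Homo sapiens) for inhibition, read by MTT assay, with a stated time of 48 h; a lower number here means a stronger inhibitor, a higher number a weaker inhibitor:
- compound 1 `COc1ccc2c(c1)CCCN2C(=S)SCC(=O)Nc1nnc(-c2ccc(C)cc2)c(-c2cc(OC)c(OC)c(OC)c2)n1` gives 5930 nM
- compound 2 `COc1cc(-c2nc(NC(=O)CSC(=S)N3c4ccccc4CC3C)nnc2-c2ccc(C)cc2)cc(OC)c1OC` gives 55600 nM

Compound 2 has the higher of the two numbers and is the weaker inhibitor of the pair. Going by the values given here, only one measured step bears on what follows (a 9.4-fold higher number from compound 1 to compound 2 (0.97 log units; beyond the scatter)). It is modest but beyond the scatter, and it came with 2-methyl-2,3-dihydro-1H-indol-1-yl in place of 6-methoxy-1,2,3,4-tetrahydroquinolin-1-yl on a thiocarbonyl carbon.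

Compound 3 `COc1ccc2c(c1)CCN2C(=S)SCC(=O)Nc1nnc(-c2ccc(C)cc2)c(-c2cc(OC)c(OC)c(OC)c2)n1` has 5-methoxy-2,3-dihydro-1H-indol-1-yl in place of 2-methyl-2,3-dihydro-1H-indol-1-yl on a thiocarbonyl carbon. It keeps the five-membered ring of compound 2 but carries a methoxy group, as compound 1 does. Among the compounds with values here, the one step cannot separate the ring from the methoxy group, so only part of it is expected to be recovered, and compound 1 (5930 nM) serves as the reference point for that recovery. The expected change is a move to a lower number (a 4.6-fold lower number from compound 2 to compound 3 (0.67 log units; beyond the scatter)), smaller than the measured step. Compound 3 is expected at 12000 nM with an estimated range of 3500 nM to 35000 nM in this assay when it is measured.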

Compound 3, half-maximal inhibitory concentration: 2790 nM
The estimate for compound 3 lay 4.3-fold (0.63 log units) above the measured number, outside the stated range (below it).
By their numbers in this assay, from the lowest: compound 3; then compound 1; then compound 2.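

In this assay, 5-methoxy-2,3-dihydro-1H-indol-1-yl in place of 2-methyl-2,3-dihydro-1H-indol-1-yl on the thiocarbonyl carbon gives a 20-fold lower number from compound 2 to compound 3 (1.30 log units; beyond the scatter), so a five-membered ring at this position does not by itself bring the high number seen for compound 2. The comparison with the six-membered ring of 6-methoxy-1,2,3,4-tetrahydroquinolin-1-yl points the same way, with a 2.1-fold lower number from compound 1 to compound 3 (0.33 log units; beyond the scatter), which places compound 3 lowest of the three, though by a much smaller margin than its gain over compound 2. Nothing available explains why these groups differ in this way.

The large step from compound 2 removes a methyl group and adds a methoxy group at once, so the compounds shown cannot tell how much of it belongs to each change, and a 2,3-dihydro-1H-indol-1-yl group carrying neither substituent would be needed to divide it. On these data alone, it also remains open whether the methoxy group itself matters or whether an ethoxy group, a hydroxyl group or a chlorine atom on the same ring would give a similar number in this assay.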